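A few compounds are considered here, and "the series" means these few. Any claim that something is new, unique, unknown or untested is made for them only; others in the source may bear on it.

The measured compounds, all tested in a functional assay on A549 cells (Homo sapiens) for antiproliferative activity, read by sulforhodamine B assay, with a stated time of 72 h; a lower number here means a stronger inhibitor, a higher number a weaker inhibitor:

Compound 1 `CC(C)C[C@H](NC(=O)CCSc1cc(NS(=O)(=O)c2cccs2)c2ccccc2c1O)B(O)O` gives 5930 nM.
Compound 2 `CC(=O)Nc1ccc(S(=O)(=O)Nc2cc(SCCC(=O)N[C@@H](CC(C)C)B(O)O)c(O)c3ccccc23)cc1` gives 5920 nM.
Compound 3 `CC(C)C[C@H](NC(=O)C(C)Sc1cc(NS(=O)(=O)c2cccs2)c2ccccc2c1O)B(O)O` gives 11300 nM.

Compound 1 and compound 2 differ in one place only, and the difference is 4-acetamidophenyl in place of thiophen-2-yl on a sulfonyl sulfur. The step that this change made is a 1.0-fold lower number from compound 1 to compound 2 (0.00 log units; within the scatter), so the two compounds cannot be told apart in this assay.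

Compound 3 shares its atoms with compound 1 but has them joined differently; the difference between the two cores is not broken down here. Its value in this assay is the highest of the three numbers, yet its steps to compound 1 and to compound 2 both lie within the scatter, so no ordering among the three is supported.

Compound 4 `CC(=O)Nc1ccc(S(=O)(=O)Nc2cc(SC(C)C(=O)N[C@@H](CC(C)C)B(O)O)c(O)c3ccccc23)cc1` has not yet been measured in this assay. It stands to compound 3 as compound 2 stands to compound 1: the difference is 4-acetamidophenyl in place of thiophen-2-yl on a sulfonyl sulfur, the same change at the same place. Because the measured pair gave a 1.0-fold lower number from compound 1 to compound 2 (0.00 log units; within the scatter), the change is expected to leave the number for compound 4 close to that of compound 3, and the step is estimated as a 1.0-fold lower number from compound 3 to compound 4 (0.01 log units; within the scatter). On that basis compound 4 is expected to give about 11000 nM in this assay, with a range estimated from 5000 nM to 24000 nM.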

Compound 4, half-maximal inhibitory concentration: 6370 nM
For compound 4 the middle estimate is 1.7-fold (0.24 log units) above the measured one; the measured number falls inside the stated range.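

Placing 4-acetamidophenyl in place of thiophen-2-yl on the sulfonyl sulfur gave, in this assay, a 1.8-fold lower number from compound 3 to compound 4 (0.25 log units; within the scatter), so compound 3 and compound 4 cannot be told apart. Set beside the same change on the core of compound 1, the two steps show no difference that can be read: the same change on two cores in this assay, a 1.0-fold lower number (0.00 log units; within the scatter) from compound 1 to compound 2 and a 1.8-fold lower number (0.25 log units; within the scatter) from compound 3 to compound 4, 1.8-fold (0.25 log units) apart, within the scatter of two such steps. This shows that, in these two pairs, the change left no effect that stands out from the scatter on either core, but it does not show that the change is without effect in general, since two pairs in a single assay cannot establish a rule for the series or predict its outcome on any other core.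

The compounds shown leave open whether any other group on the sulfonyl sulfur, such as a phenyl ring carrying a carboxylic acid or an amine, would produce a step beyond the scatter in this assay. They also leave open how a longer chain on the thioether sulfur would behave, and whether the swap of thiophen-2-yl for 4-acetamidophenyl would remain without a readable effect there.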